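Thiophen-2-yl in place of naphthalen-1-yl on compound 2

A few compounds are considered here, and "the series" means these few. Any claim that something is new, unique, unknown or untested is made for them only; others in the source may bear on it.

Compound 1 `COc1ccc(/C=C/C(=O)/C=C/c2ccc(OCc3cn(CCCCOc4cc(=O)oc5ccccc45)nn3)c(OC)c2)cc1OC` gives 59%
Compound 2 `COc1cc(/C=C/C(=O)/C=C/c2cccc3ccccc23)ccc1OCc1cn(CCCCCOc2cc(=O)oc3ccccc23)nn1` gives 44%
Compound 3 `COc1cc(/C=C/C(=O)/C=C/c2ccco2)ccc1OCc1cn(CCCOc2cc(=O)oc3ccccc23)nn1` gives 57%

In a functional assay on THP-1 cells (Homo sapiens) for inhibition, read by sulforhodamine B assay, with a stated time of 48 h, tested at 50 uM (on this read-out higher numbers stand for more inhibition of growth at the one concentration tested and lower numbers for less inhibition of growth), compound 2 gives 44% as the lowest of the three numbers. Compound 4 `COc1cc(/C=C/C(=O)/C=C/c2cccs2)ccc1OCc1cn(CCCCCOc2cc(=O)oc3ccccc23)nn1` is still unmeasured. It has thiophen-2-yl in place of naphthalen-1-yl on a double-bonded chain carbon bound to a double-bonded chain carbon and is otherwise the same as compound 2. Among the compounds with values here, compound 3 at 57% and compound 1 at 59% each stand higher than compound 2 by more than the scatter, so a small upward step is expected in this assay even though no measured pair shows this change alone. The expected size is a number 8 percentage points higher from compound 2 to compound 4 (within the scatter) and may not clear the scatter. For compound 4 the estimated value is 52% with an expected range from 38% to 65% for the measurement.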

Compound 4, percent growth inhibition at one concentration: 34%
For compound 4 the middle estimate is 18 percentage points above the measured one, and the stated range ends above it.
By their numbers in this assay, from the lowest: compounds 4 and 2 (each within the scatter of the next); then compounds 3 and 1 (each within the scatter of the next).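

In this assay, within the data shown here, putting thiophen-2-yl in place of naphthalen-1-yl gives a number 10 percentage points lower from compound 2 to compound 4 (within the scatter), so this single change at this position shows no step that clears the usual scatter. Compound 1 and compound 3 differ from compound 2 in more than one place, so their numbers cannot be credited to the ring at this position alone. Nothing measured here explains the step. On these data alone, it remains open how a carboxylic acid or an amine would read at this position, and how thiophen-2-yl would read on the chains of compound 1 and compound 3.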